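Hydroxymethyl to aminomethyl on the chloropyridyl sulfonamide core

The source may hold more compounds than are shown below. What is called first, only, known or untested is meant among the compounds shown, and "the series" means these compounds.

Measured compounds:
compound 1 `N#Cc1ccc(O[C@H]2CN(S(=O)(=O)c3ccc(Cl)cc3Cl)C[C@@]2(O)CN)cc1F`: 4
compound 2 `N#Cc1ccc(O[C@H]2CN(S(=O)(=O)c3ccc(Cl)cn3)C[C@@]2(O)CO)cc1F`: 3.4
compound 3 `N#Cc1ccc(O[C@H]2CN(S(=O)(=O)c3ccc(Cl)cn3)C[C@]2(O)CO)cc1F`: 3.5

In a physicochemical assay for lipophilicity, at pH 7.4 (on this read-out lower numbers stand for lower lipophilicity and higher numbers for higher lipophilicity), compound 2 gives 3.4, the lowest of the three numbers. Compound 3, which shares its atoms and bonds and differs only in the configuration drawn at one saturated ring carbon, sits a number 0.10 log units higher from compound 2 to compound 3 (within the scatter); this is within the scatter and is consistent with the fact that compounds 2 and 3 differ only in the configuration as drawn. Compound 1 differs from compound 2 in two places. In this assay compound 1 gives 4. For the measured compounds named here, no single step connects compound 1 to compound 2, so its value is noted only as a comparison point.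

Compound 4 `N#Cc1ccc(O[C@H]2CN(S(=O)(=O)c3ccc(Cl)cn3)C[C@@]2(O)CN)cc1F` is not yet measured. It differs from compound 2 by amino in place of hydroxy on a saturated chain carbon bound to a saturated ring carbon. Going by the values given here, none of the measured steps carries this change: the only measured step is a configurational one and lies within the scatter, so it gives no guidance on the direction or size here. The expectation rests on the change alone and is uncertain. Compound 4 is estimated to come out at 2.8 in this assay, with a range of 2.2 to 3.4. The step that this estimate implies, a number 0.60 log units lower from compound 2 to compound 4 (beyond the scatter), is expected to be beyond the scatter but is not supported by a measured pair.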

Compound 4, distribution coefficient: 2.5
For compound 4 the middle estimate is 0.30 log units above the measured one; measured number inside the range.
By their numbers in this assay, from the lowest: compound 4; then compounds 2 and 3 (each within the scatter of the next); then compound 1.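

Swapping hydroxymethyl for aminomethyl moves the number in this assay by a number 0.90 log units lower from compound 2 to compound 4 (beyond the scatter), so the group on this saturated chain carbon matters in a way that the configurational pair, compound 2 and compound 3, did not show. With aminomethyl held constant, 5-chloropyridin-2-yl in place of 2,4-dichlorophenyl on the sulfonyl sulfur gives a number 1.50 log units lower from compound 1 to compound 4 (beyond the scatter), so the sulfonyl substituent also shifts the read-out, by a step classed as large against the modest one for the chain change. Nothing measured here accounts for either step.

Going by these compounds, it remains open whether the hydroxymethyl to aminomethyl step holds with the ring carbon in the configuration of compound 3, or with 2,4-dichlorophenyl on the sulfonyl sulfur. A dimethylaminomethyl group, a carboxylic acid or a longer aminoalkyl chain in the same place also remains to be placed on this scale.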